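Notes on a benzyl-protected pyranose series, ring substituent change

A few compounds are considered here, and "the series" means these few. Any claim that something is new, unique, unknown or untested is made for them only; others in the source may bear on it.

Measured so far:
Compound 1 `CCCC[C@@H]1O[C@H](COCc2ccccc2)[C@@H](OCc2ccccc2)[C@H](OCc2ccccc2)[C@H]1O`: in a functional assay on HeLa cells (Homo sapiens) for antiproliferative activity, read by sulforhodamine B assay (on this read-out higher numbers stand for weaker inhibition of growth and lower numbers for stronger inhibition of growth), compound 1 gives > 50000 nM, which is a limit of the assay.
Compound 2 `CC(C)C[C@@H]1O[C@H](COCc2ccccc2)[C@@H](OCc2ccccc2)[C@H](OCc2ccccc2)[C@H]1O`: in this assay compound 2 gives > 50000 nM, again a limit of the assay.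
Compound 3 `OCC[C@@H]1O[C@H](COCc2ccccc2)[C@@H](OCc2ccccc2)[C@H](OCc2ccccc2)[C@H]1O`: in this assay compound 3 gives 30200 nM.

Among the compounds with values here, compound 3 thus holds the only number in the set; the other two values are limits, as the limit of > 50000 nM in this assay, at which 2 of the 3 values shown sit, shows. Compound 4 `O[C@@H]1[C@@H](OCc2ccccc2)[C@H](OCc2ccccc2)[C@@H](COCc2ccccc2)O[C@H]1c1ccccc1` is the next entry and has not yet been measured. Its change from compound 3 is phenyl in place of 2-hydroxyethyl on a saturated ring carbon. Within the data shown here, two measured steps bear on it: an at least 1.6-fold lower number from compound 1 to compound 3 (0.21 log units; that floor lies within the scatter) and an at least 1.6-fold lower number from compound 2 to compound 3 (0.21 log units; that floor lies within the scatter). Both put a hydroxy-bearing chain in place of propyl or isopropyl, and both reach only a floor that lies within the scatter. Compound 4 removes the hydroxy again and carries a phenyl, a group absent from all three measured compounds. The nearest guide is what compounds 1 and 2 show, so a higher number, possibly again a limit, is expected, with its size not firmly readable. Compound 4 is therefore estimated at 45000 nM, between 15000 nM and 120000 nM. This estimate means the expected step of a 1.5-fold higher number from compound 3 to compound 4 (0.17 log units; within the scatter), a return toward the limit seen for the propyl and isopropyl compounds.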

Compound 4, concentration for 50% growth inhibition: > 50000 nM
Compound 4: no number, only a limit; the forecaster's own chance of this, stated with the estimate: 50%; middle value at least 1.1-fold (0.04 log units) from the limit.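

Phenyl is the first ring-bearing group at this saturated ring carbon next to the ring oxygen, and in this assay its entry in place of 2-hydroxyethyl gives an at least 1.6-fold higher number from compound 3 to compound 4 (0.21 log units; that floor lies within the scatter), so this change alone does not establish a loss of growth inhibition. Compound 4 gives > 50000 nM, which is a limit of the assay. The steps to compound 4 from compound 1 and from compound 2 join two limits and cannot be read, but the series now shows that an aromatic ring at this carbon, like butyl and isobutyl, gives no number, leaving compound 3 as the only compound with one: the limit of > 50000 nM in this assay, at which 3 of the 4 values shown sit.

The compounds shown leave open whether the number for compound 3 depends on the hydroxy group itself or on the chain that carries it, and an amine or a carboxylic acid at the end of that chain lies outside the set. Also open, on these data alone, is whether a phenyl ring carrying a hydroxy group, or a longer hydroxyalkyl chain, would give a number at this carbon.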